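This account rests on a few compounds, and the source may have more. Where it says the series, first, only, none or still open, it means among the compounds named here.

Going by the values given here, compound 2 `O=C(C(Nc1ccccc1F)c1ccc(C(F)(F)F)cc1)N1CCCC1c1ccc(F)cc1` gives 37 nM in an assay on HEK293 cells for antagonist activity at transient receptor potential M8 protein (Canis lupus familiaris), read by fluorescence and calcium flux, with a stated time of 5 min (on this read-out lower numbers stand for stronger inhibition and higher numbers for weaker inhibition), the highest of the two numbers so far. Compound 1 `O=C(C(Nc1ccccc1F)c1ccc(C(F)(F)F)cc1)N1CCCC1c1ccccc1F` gives 7 nM in this assay. Among the compounds with values here, the single measured step, a 5.3-fold higher number from compound 1 to compound 2 (0.72 log units; beyond the scatter), separates the 2-fluorophenyl of compound 1 from the 4-fluorophenyl of compound 2 on the saturated ring carbon. Compound 3 `O=C(C(Nc1ccccc1F)c1ccc(C(F)(F)F)cc1)N1CCCC1c1ccccc1Cl` is not yet measured; its change from compound 2 is 2-chlorophenyl in place of 4-fluorophenyl on a saturated ring carbon. The 2-chlorophenyl of compound 3 matches the 2-fluorophenyl of compound 1 except for the halogen, so the measured step bears on it directly, and that step was beyond the scatter. A lower number for compound 3 is therefore expected, with a step estimated at about a 4.6-fold lower number from compound 2 to compound 3 (0.67 log units; beyond the scatter). No fluorine-to-chlorine comparison has been measured in this series, so the range is kept wide. The estimate for compound 3 in this assay is 8 nM, between 3 nM and 25 nM.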

Compound 3, half-maximal inhibitory concentration: 11 nM
Estimate against measurement, compound 3: 1.4-fold (0.14 log units) below, and the stated range covers the measured number.
By their numbers in this assay, from the lowest: compounds 1 and 3 (each within the scatter of the next); then compound 2.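

In this assay, the change to 2-chlorophenyl gives a 3.4-fold lower number from compound 2 to compound 3 (0.53 log units; beyond the scatter), so a second group now stands clear of the 4-fluorophenyl of compound 2 at this saturated ring carbon. Chloro in place of fluoro on the aromatic carbon gives a 1.6-fold higher number from compound 1 to compound 3 (0.20 log units; within the scatter), so the two halogens cannot be told apart here when they sit in the same place on the phenyl ring. The step from compound 2 changes the halogen and its place together, but across these three compounds the numbers follow the place of the halogen and not its identity.

Still open, from the compounds shown here alone, is whether an unsubstituted phenyl, a 2-methoxyphenyl or a 4-chlorophenyl group would fit that reading. No supporting information on hand explains the difference between the 2-halophenyl and 4-fluorophenyl groups.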